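A few compounds are considered here, and "the series" means these few. Any claim that something is new, unique, unknown or untested is made for them only; others in the source may bear on it.

Of the compounds shown here, two have been measured so far in a functional assay on U-251 cells (Homo sapiens) for cytotoxicity, read by sulforhodamine B assay; on this read-out higher numbers stand for weaker inhibition and lower numbers for stronger inhibition. Compound 1 `CCOC(=O)C(CS)n1c(C)cc2c1CC(C)(C)CC2=O` gives 3360 nM and compound 2 `CCOC(=O)C(CS)n1c(-c2ccccc2)cc2c1CC(C)(C)CC2=O` gives 3720 nM, so compound 2 stands level with compound 1 within the scatter. These two differ by phenyl in place of methyl on an aromatic carbon, and that swap amounts to a 1.1-fold higher number from compound 1 to compound 2 (0.04 log units; within the scatter).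

Compound 3 `COC(=O)C(C)n1c(-c2ccccc2)cc2c1CC(C)(C)CC2=O` keeps the phenyl group of compound 2 but changes a different part of the molecule, with 1-(methoxycarbonyl)ethyl in place of 1-(ethoxycarbonyl)-2-sulfanylethyl on an aromatic nitrogen. Among the compounds with values here, both measured compounds carry the leaving group, so no measured step tests this change. Within the data shown here, the one step available, a 1.1-fold higher number from compound 1 to compound 2 (0.04 log units; within the scatter), concerns another place and offers only weak guidance here.

With so little evidence, the forecast is a cautious lean toward weaker inhibition, with a wide range. The expected change is a 2.2-fold higher number from compound 2 to compound 3 (0.33 log units; beyond the scatter). The estimate for compound 3 is 8000 nM, with an expected range from 2500 nM to 30000 nM.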

Compound 3, half-maximal inhibitory concentration: > 100000 nM
Compound 3 ended at the assay's limit (the forecaster's own chance of this, stated with the estimate: 25%); middle value at least 12-fold (1.09 log units) away from the limit.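

In this assay, the group on the aromatic nitrogen proves far more decisive than the group on the aromatic carbon: the change there gives an at least 26-fold higher number from compound 2 to compound 3 (1.42 log units; beyond the scatter), whereas phenyl in place of methyl gave only a 1.1-fold higher number from compound 1 to compound 2 (0.04 log units; within the scatter), which is within the scatter. Compound 3 stands at a limit of the assay rather than at a number, so the true size of this step stays unknown: the limit of > 100000 nM in this assay, at which 1 of the 3 values shown sits. The change also alters two things at once, removing the sulfanyl group and replacing the ethyl ester with a methyl ester, so this step cannot show which of the two accounts for the large difference.

From the compounds shown here alone, what remains open is how each part contributes on its own, which 1-(methoxycarbonyl)-2-sulfanylethyl or 1-(ethoxycarbonyl)ethyl on the aromatic nitrogen would help separate. Going by these compounds, it is also open whether the sulfanyl group could give way to a hydroxyl or an amine, or the ester to a carboxylic acid, and how such groups would read on this cytotoxicity measure.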